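Hexyl ether in place of aryl ether on the benzoyl oxazolidinone

A few compounds are considered here, and "the series" means these few. Any claim that something is new, unique, unknown or untested is made for them only; others in the source may bear on it.

Measured compounds:
compound 1 `O=C(CCCCCc1cccc(O)c1)N1CCOC1=O`: 8640 nM
compound 2 `O=C(CCCCCc1cccc(C(F)(F)F)c1)N1CCOC1=O`: 58 nM
compound 3 `Cc1ccc(Oc2ccc(C(=O)N3CCOC3=O)cc2)cc1`: 6400 nM

In an assay on HEK293 cells for inhibition of N-acylethanolamine-hydrolyzing acid amidase (Rattus norvegicus), read by LC-MS, with a stated time of 30 min (a higher number here means a weaker inhibitor, a lower number a stronger inhibitor), compound 3 stands second highest of the three numbers. Its nearest neighbour is compound 1, and the two values lie within the usual scatter of each other; compound 2 sits far lower, beyond the scatter. Going by the values given here, the one step on record, a 150-fold lower number from compound 1 to compound 2 (2.17 log units; beyond the scatter), concerns a change on the aromatic ring of the phenylpentanoyl series and does not touch the ether oxygen of compound 3.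

Compound 4 `CCCCCCOc1ccc(C(=O)N2CCOC2=O)cc1` is the next analogue: hexyl in place of 4-methylphenyl on an oxygen on an aromatic ring. Among the compounds with values here, no measured pair in this assay shares this change, so there is no step that bears on it directly. Within the data shown here, a flexible chain on the oxygen is the only comparator-free guide, and the data give no step to lean on, so only a modest shift is expected: a 1.8-fold lower number from compound 3 to compound 4 (0.26 log units; within the scatter), with wide uncertainty. The expected value for compound 4 is 3500 nM, estimated to fall between 800 nM and 15000 nM.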

Compound 4, half-maximal inhibitory concentration: 640 nM
Compound 4: the middle estimate sits 5.5-fold (0.74 log units) above what was measured, and the stated range ends above it.
By their numbers in this assay, from the lowest: compound 2; then compound 4; then compounds 3 and 1 (each within the scatter of the next).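

In this assay, the group on an oxygen on an aromatic ring proves to be a position that matters: hexyl in place of 4-methylphenyl gives a 10-fold lower number from compound 3 to compound 4 (1.00 log units; beyond the scatter), a step beyond the scatter. An open chain with no ring therefore does better on this core than the 4-methylphenyl ether, something the earlier step, a change on the aromatic ring of a different series, could not show. Nothing at hand accounts for the size of this step.

On these data alone, what remains open is how the number depends on the chain itself: whether a butyl or an octyl chain on the same oxygen would hold or extend the drop. Also open, as far as these compounds go, is whether a cyclohexyl ring, or a hexyl chain ending in an amine or a carboxylic acid, would keep it.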